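A few compounds are considered here, and "the series" means these few. Any claim that something is new, unique, unknown or untested is made for them only; others in the source may bear on it.

Compound 1 `O=C(Nc1nccn2cc(-c3ccccc3)nc12)c1ccccc1` stands highest of the two numbers in an assay on cells for displacement of a labelled ligand from adenosine receptor A1 (Homo sapiens), read by scintillation counting, with a stated time of 120 min, tested at 1 uM (on this read-out higher numbers stand for more inhibition at the one concentration tested (going by the name of the read-out) and lower numbers for less inhibition), where compound 1 gives 18%. Its nearest neighbour is compound 2 `O=C(c1ccccc1)N(C(=O)c1ccccc1)c1nccn2cc(-c3ccccc3)nc12`, which in this assay gives 4%. Going by the values given here, the only measured step, a number 14 percentage points lower from compound 1 to compound 2 (beyond the scatter), concerns the amide nitrogen and not the phenyl ring, so it does not bear on the change toward compound 3 `COc1ccc(C(=O)Nc2nccn3cc(-c4ccccc4)nc23)cc1`. That change is methoxy in place of hydrogen on an aromatic carbon. With nothing measured at this position, compound 3 is expected to give about 18%, within a range of 5% to 35%. The step expected is no change at the digits printed from compound 1 to compound 3 (within the scatter), which would remain within the scatter.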

Compound 3, a percentage reported as inhibition, at one concentration (the size of the read-out at that concentration, not a potency): 1%
Estimate against measurement, compound 3: 17 percentage points above; the whole stated range lies above it.
By their numbers in this assay, from the lowest: compounds 3 and 2 (each within the scatter of the next); then compound 1.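

Methoxy on the phenyl ring, para to a large group, brings a number 17 percentage points lower from compound 1 to compound 3 (beyond the scatter) in this assay and so shows that this ring, which the earlier compounds left unchanged, is also a place where a substitution lowers the number. This rests on the single group shown at this position. Nothing available explains the fall.

On these data alone, whether a fluorine atom, an amine or a carboxylic acid at the same place would also lower the number, or raise it, stays open. So does the effect of a longer chain, such as ethoxy, in place of methoxy.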